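A Chloro Group on an Unmoved Cytotoxicity Value

The compounds below may be only part of what the source reports. "The series", "measured", "known", "first", "only" and "open" are said of these compounds alone.

In a functional assay on B16-F10 cells (Mus musculus) for cytotoxicity (a higher number here means a weaker inhibitor, a lower number a stronger inhibitor), compound 1 `O=c1oc2ccccc2c2nc3c(ccc4cc[nH]c43)c(-c3cccc4ccccc34)c12` gives 70700 nM. Compound 2 `O=c1oc2ccccc2c2nc3c(ccc4cc[nH]c43)c(-c3ccccc3)c12` gives 70700 nM, so the two stand level, and both need a high concentration to act on these cells. The next compound, compound 3 `O=c1oc2ccccc2c2nc3c(ccc4cc[nH]c43)c(-c3ccc(Cl)cc3)c12`, keeps everything in compound 2 except for one small edit: chloro in place of hydrogen on an aromatic carbon, which turns phenyl to 4-chlorophenyl.

Among the compounds with values here, only one measured step bears on this edit. It is no change at the digits printed from compound 1 to compound 2 (within the scatter), made by putting phenyl in place of naphthalen-1-yl on an aromatic carbon. That is a single comparison and a thin guide, but it concerns the same substituent that now gains the chloro. Within the data shown here, with only that step to go on, no shift beyond the scatter is expected in this assay, and no direction can be favoured. The expected size of the change is a 1.2-fold lower number from compound 2 to compound 3 (0.07 log units; within the scatter). For compound 3 the estimated value is 60000 nM, with an expected range of 25000 nM to 110000 nM.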

Compound 3, half-maximal inhibitory concentration: 70700 nM
Compound 3: the middle estimate sits 1.2-fold (0.07 log units) below what was measured; the measured number falls inside the stated range.
By their numbers in this assay, from the lowest: compounds 1, 2 and 3 (each within the scatter of the next).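

Within the data shown here, the chloro edit (no change at the digits printed from compound 2 to compound 3 (within the scatter)) is the first reading for a small group added to the phenyl ring, para to a large group, rather than for a swap of the whole ring system. The exchange of naphthalen-1-yl for 4-chlorophenyl (no change at the digits printed from compound 1 to compound 3 (within the scatter)) completes the picture, so in this assay three different groups on this aromatic carbon now stand level. No measurement shown here accounts for this flat result.

An amine or a carboxylic acid in place of the chloro might or might not move the number, and the compounds shown cannot settle that. They also leave open whether any group at this site can shift the value, and whether edits elsewhere on the shared core would do so.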